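Exchanging a phenyl for methoxymethyl on the cyclobutyl side chain

The source may report more compounds than this note shows. Statements on the series, on what has been measured and on what is new or still open speak of the compounds shown alone.

Measured so far:
compound 1 `O=C(O)c1csc(SCCN2C(=O)OC[C@@H]2/C=C/[C@@H](O)C2(CCCCF)CCC2)n1`: 195 nM
compound 2 `O=C(O)c1csc(SCCN2C(=O)OC[C@@H]2/C=C/[C@@H](O)C2(CCc3ccccc3)CCC2)n1`: 465 nM

Both compounds were assessed in an assay on isolated protein for agonist activity at prostaglandin E2 receptor EP4 subtype (Homo sapiens); on this read-out higher numbers stand for an effect only at larger amounts of compound and lower numbers for an effect already at smaller amounts. Within the data shown here, compound 2 gives the highest of the two numbers; its nearest neighbour is compound 1, and the one measured step, a 2.4-fold higher number from compound 1 to compound 2 (0.38 log units; beyond the scatter), separates them. Compound 3 `COCCCC1([C@H](O)/C=C/[C@H]2COC(=O)N2CCSc2nc(C(=O)O)cs2)CCC1` differs from compound 2 by a single change: methoxymethyl in place of phenyl on a saturated chain carbon, two bonds along the chain from a saturated ring carbon. Among the measured compounds shown here, no measured pair shows this exact exchange. For the measured compounds named here, the only step that bears on it is a 2.4-fold higher number from compound 1 to compound 2 (0.38 log units; beyond the scatter), in which a short chain bearing a heteroatom was replaced by phenyl and the number rose modestly. Compound 3 reverses that kind of exchange, putting a short chain with one hydrogen-bond acceptor in place of phenyl, so a modest downward step a 1.9-fold lower number from compound 2 to compound 3 (0.27 log units; within the scatter) is expected, back toward the level of compound 1. Compound 3 is therefore estimated at 250 nM in this assay, with a range from 100 nM to 650 nM.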

Compound 3, half-maximal effective concentration: 705 nM
Compound 3: middle estimate off by 2.8-fold (0.45 log units), on the low side; measured number outside the range, above it.
By their numbers in this assay, from the lowest: compound 1; then compounds 2 and 3 (each within the scatter of the next).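

In this assay, methoxymethyl in place of phenyl on a saturated chain carbon, two bonds along the chain from a saturated ring carbon, gives a 1.5-fold higher number from compound 2 to compound 3 (0.18 log units; within the scatter) and so leaves the number unresolved from that of the phenyl compound, even though the ring is gone and a hydrogen-bond acceptor has entered. A chain bearing a heteroatom therefore does not by itself return the number to the level of compound 1: methoxy in place of fluoromethyl gives a 3.6-fold higher number from compound 1 to compound 3 (0.56 log units; beyond the scatter) and is the larger of the two new steps. Nothing available explains these results.

The compounds shown leave open whether a hydroxyl, an amine or a carboxylic acid in place of methoxymethyl would separate from compounds 2 and 3. They also leave open whether a longer chain ending in fluorine would stay at the level of compound 1.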